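The compounds below may be only part of what the source reports. "The series", "measured", "known", "first", "only" and "open" are said of these compounds alone.

Compound 3 `CCCNc1ncnc2c1ncn2CC1CC1` gives 0% in a functional assay on the whole organism for inhibition, with Rattus norvegicus as the target, at a dose of 25 mg/kg by the intraperitoneal route; on this read-out higher numbers stand for more inhibition at the one dose given (going by the name of the read-out) and lower numbers for less inhibition. Compound 1 `CCN(CC)c1ncnc2c1ncn2CC1CC1` gives 0% and compound 2 `c1nc(N2CCC2)c2ncn(CC3CC3)c2n1` gives 30%, so compound 3 stands level with compound 1, the two together being the lowest numbers of the three. The only rise measured is a number 30 percentage points higher from compound 1 to compound 2 (beyond the scatter); the return is a number 30 percentage points lower from compound 2 to compound 3 (beyond the scatter), and no change at the digits printed from compound 1 to compound 3 (within the scatter). Compound 4 `c1nc(NC2CCC2)c2ncn(CC3CC3)c2n1` carries the change (cyclobutyl in place of propyl on a nitrogen on an aromatic ring). Going by the values given here, the single step that introduced a four-membered ring on the nitrogen on the aromatic ring, a number 30 percentage points higher from compound 1 to compound 2 (beyond the scatter), was modest and upward, though there the whole amine became the ring, whereas cyclobutylamino keeps the amine hydrogen, a case not yet measured. A small upward step is expected, a number 15 percentage points higher from compound 3 to compound 4 (beyond the scatter), with wide uncertainty. Compound 4 is thus estimated at 15%, spanning 0% to 40%.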

Compound 4, a percentage reported as inhibition, in the whole organism at one dose (the size of the read-out at that dose, not a potency): 0%
Compound 4: middle estimate off by 15 percentage points, on the high side, and the stated range covers the measured number.
By their numbers in this assay, from the lowest: compounds 1, 3 and 4 (each within the scatter of the next); then compound 2.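

In this assay, turning the propyl into a cyclobutyl on the nitrogen on the aromatic ring gives no gain (no change at the digits printed from compound 3 to compound 4 (within the scatter)), so a four-membered ring with the amine hydrogen kept does not reproduce the level of compound 2. Cyclobutylamino also falls short of azetidin-1-yl (a number 30 percentage points lower from compound 2 to compound 4 (beyond the scatter)) and sits level with diethylamino (no change at the digits printed from compound 1 to compound 4 (within the scatter)), leaving azetidin-1-yl alone among these groups. No available evidence bears on the reason for this difference.

From the compounds shown here alone, whether pyrrolidin-1-yl or piperidin-1-yl in place of azetidin-1-yl would hold the inhibition of compound 2 remains open.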